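Three ureas on one quinoline core and a methyl removal

This account rests on a few compounds, and the source may have more. Where it says the series, first, only, none or still open, it means among the compounds named here.

Three ureas sharing a common core have been run in an ADME assay for permeability, using PAMPA, at pH 7.4; a lower number here means that the compound crosses the layer more slowly, a higher number that the compound crosses the layer faster. Compound 1 `Cc1cc(NC(=O)Nc2ccc(C)c(Cl)c2)c2ccccc2n1` gives 262 10^-6 cm/s and sits second highest of the three numbers. Compound 3 `Cc1cc(NC(=O)Nc2ccccc2C(F)(F)F)c2ccccc2n1` gives 945 10^-6 cm/s, a step upward from compound 1 that lies beyond the scatter. Compound 2 `Cc1cc(NC(=O)Nc2ccc([N+](=O)[O-])c(C(F)(F)F)c2)c2ccccc2n1`, which carries a nitro group and a trifluoromethyl group on the aryl ring, gives 45 10^-6 cm/s, the lowest number of the set and a step downward from compound 1 that also lies beyond the scatter. Thus compound 1 stands between compound 3 and compound 2, nearer to compound 3 on the log scale.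

Compound 4 `Cc1cc(NC(=O)Nc2cccc(Cl)c2)c2ccccc2n1` has not yet been measured in this assay. Its difference from compound 1 is hydrogen in place of methyl on an aromatic carbon. Within the data shown here, no step between two measured compounds matches this change, so the expectation rests only on the three values above. The change removes one carbon and leaves the chloro group in place. The step from compound 1 to compound 4 is expected to be small, downward if anything, and likely to stay within the scatter: a 1.3-fold lower number from compound 1 to compound 4 (0.12 log units; within the scatter). Compound 4 is therefore expected to give about 200 10^-6 cm/s in this assay, with a plausible range from 100 10^-6 cm/s to 400 10^-6 cm/s.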

Compound 4, apparent permeability: 566 10^-6 cm/s
Beside the measured number, compound 4's estimate is 2.8-fold (0.45 log units) below it, and the stated range ends below it.
By their numbers in this assay, from the lowest: compound 2; then compound 1; then compounds 4 and 3 (each within the scatter of the next).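

In this assay, replacing the methyl with hydrogen on the aromatic carbon ortho to a chloro group and para to a large group gives a 2.2-fold higher number from compound 1 to compound 4 (0.33 log units; beyond the scatter) and shows that this position is not silent to the loss of one carbon: the step is modest, but it lies beyond the scatter and points upward. Among these compounds, this is the first pair that differs in one place, so it gives the first direct reading of a single change on this ring, which compounds 1, 2 and 3 could not give among themselves. Nothing at hand bears on why the number rises with this change.

One pair fixes the size and direction of the step for this one setting only, with the chloro group and the shared core held constant. Open questions are where a methoxy group, a fluoro group or an ethyl chain on the same carbon would fall relative to hydrogen and methyl, and whether removing the methyl gives a similar step when a bromo group or a trifluoromethyl group stands in place of the chloro group.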